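Swapping the acylamino group on an ester-bearing scaffold

This account rests on a few compounds, and the source may have more. Where it says the series, first, only, none or still open, it means among the compounds named here.

Measured in a functional assay on Rec1 cells (Homo sapiens) for inhibition, read by luminescence and CellTiter-Glo, with a stated time of 72 h; a higher number here means a weaker inhibitor, a lower number a stronger inhibitor:
- compound 1 `O=C(CCl)Nc1ccc(Cn2nc(-c3ccc(Oc4ccccc4)cc3)cc2CO)cc1` gives 400 nM here
- compound 2 `C/C=C/C(=O)Nc1ccc(Cn2nc(-c3ccc(Oc4ccccc4)cc3)cc2C(=O)OCC)cc1` gives 13100 nM here
- compound 3 `C=CC(=O)Nc1cccc(Cn2nc(-c3ccc(Oc4ccccc4)cc3)cc2C(=O)OCC)c1` gives 3300 nM here

Of these three numbers, compound 3 (3300 nM) holds the middle place. Compound 2 lies higher and compound 1 lies lower, both beyond the usual scatter.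

The next compound, compound 4 `CCOC(=O)c1cc(-c2ccc(Oc3ccccc3)cc2)nn1Cc1ccc(NC(=O)CCl)cc1`, keeps the ethyl ester of compound 3 and changes one group: 4-(((chloromethyl)carbonyl)amino)phenyl in place of 3-((vinylcarbonyl)amino)phenyl on a saturated chain carbon bound to an aromatic nitrogen. In words, a 4-(((chloromethyl)carbonyl)amino)phenyl enters in place of the 3-((vinylcarbonyl)amino)phenyl, on a saturated chain carbon bound to an aromatic nitrogen.

Going by the values given here, only one measured step touches this place, a 4.0-fold lower number from compound 2 to compound 3 (0.60 log units; beyond the scatter), and it is modest. It shows that the number responds to changes in this group, but it does not cover the entering group. Compound 1 (400 nM) does carry the entering group, though on a core that differs from that of compound 4, so it offers only indirect support for a lower number.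

The expected move in this assay is therefore downward and modest, an estimated 3.3-fold lower number from compound 3 to compound 4 (0.52 log units; beyond the scatter) and so toward a stronger inhibitor. The estimated value for compound 4 is 1000 nM within an expected range from 300 nM to 3500 nM (not yet measured).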

Compound 4, half-maximal inhibitory concentration: 400 nM
For compound 4 the middle estimate is 2.5-fold (0.40 log units) above the measured one; measured number inside the range.
By their numbers in this assay, from the lowest: compounds 1 and 4 (each within the scatter of the next); then compound 3; then compound 2.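

In this assay the plainest new reading is a 33-fold lower number from compound 2 to compound 4 (1.52 log units; beyond the scatter), where only chloromethyl replaces prop-1-en-1-yl on a carbonyl carbon, so the group on that carbonyl can produce a large step where the earlier step at this place was modest. The other change at this place, an 8.3-fold lower number from compound 3 to compound 4 (0.92 log units; beyond the scatter), points the same way, but it exchanges the whole 3-((vinylcarbonyl)amino)phenyl for the 4-(((chloromethyl)carbonyl)amino)phenyl, so the effects of the acyl group and of its place on the ring cannot be told apart. With the 4-(((chloromethyl)carbonyl)amino)phenyl held constant, no change at the digits printed from compound 1 to compound 4 (within the scatter) shows that ethoxycarbonyl and hydroxymethyl on an aromatic carbon give numbers that cannot be separated in this assay. Nothing available explains these steps.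

On these data alone, it remains open how a 3-(((chloromethyl)carbonyl)amino)phenyl or a 4-((vinylcarbonyl)amino)phenyl would read, and either one would separate the two changes made together in going to compound 4. Also open, as far as these compounds go, is whether a plain methyl on the same carbonyl would keep the number, or whether a carboxylic acid or a primary amide in place of the ethoxycarbonyl would.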